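The source may hold more compounds than are shown below. What is called first, only, known or untested is meant among the compounds shown, and "the series" means these compounds.

Compound 1 `CC1(C)[C@@H](Cn2cnc3c(O)nc(N)nc32)CC[C@@]1(C)CO`: in an ADME assay on L1210/0 cells (Mus musculus) for cytotoxicity, with a stated time of 48 h (a lower number here means a stronger inhibitor, a higher number a weaker inhibitor), compound 1 gives > 200000 nM, which is a limit of the assay.
Compound 2 `O=c1[nH]c(=O)n([C@H]2C[C@H](O)[C@@H](CO)O2)cc1/C=C/I`: in this assay compound 2 gives 63900 nM.
Compound 3 `O=c1[nH]c(=O)n(C[C@H]2CCC[C@H]2CO)cc1I`: in this assay compound 3 gives > 200000 nM, again a limit of the assay.

Among the compounds with values here, compound 2 is therefore the only compound here with a real number; the other two sit at the limit of > 200000 nM in this assay, at which 2 of the 3 values shown sit. Compound 4 `O=c1[nH]c(=O)n([C@H]2C[C@H](O)[C@@H](CO)O2)cc1C#CCO` is not yet measured. It differs from compound 2 in one place: 3-hydroxyprop-1-yn-1-yl in place of 2-iodoethenyl on an aromatic carbon. No measured step in this assay connects two of these compounds, so the direction of the change must be estimated. Within the data shown here, the step from compound 2 to compound 4 is expected to be a 2.3-fold higher number from compound 2 to compound 4 (0.37 log units; beyond the scatter), weakening, since the loss of the iodine-bearing group removes the one feature that set compound 2 apart from the two limit compounds. For compound 4 an expected value of 150000 nM is estimated, between 40000 nM and 200000 nM.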

Compound 4, half-maximal inhibitory concentration: > 200000 nM
Compound 4 was reported as a limit; the forecaster's own chance of this, stated with the estimate: 40%; middle value at least 1.3-fold (0.12 log units) away from the limit.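

Within the data shown here, replacing 2-iodoethenyl with 3-hydroxyprop-1-yn-1-yl on this aromatic carbon gives the only readable step in this assay, an at least 3.1-fold higher number from compound 2 to compound 4 (0.49 log units; beyond the scatter). The change at this one position is therefore enough to move the compound out of the measurable range, so the shared core alone does not give compound 2 its number. Compound 4 gives a limit rather than a number, and it joins the other compounds there: the limit of > 200000 nM in this assay, at which 3 of the 4 values shown sit.

As far as these compounds go, the full size of the step stays open, as does whether the iodine or the double bond matters more. A 2-bromoethenyl group or an ethenyl group without a halogen at this carbon would help separate the two.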